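The compounds below may be only part of what the source reports. "The series", "measured", "known", "first", "only" and "open" are said of these compounds alone.

Compound 3 `O=S(=O)(c1ccccc1)c1nc2ccccc2nc1Nc1ccc(Cl)cc1` gives in a functional assay on PC-3 cells (Homo sapiens) for cytotoxicity, read by MTT assay, with a stated time of 72 h (a lower number here means a stronger inhibitor, a higher number a weaker inhibitor), 15300 nM, the highest number of the three measured compounds. Compound 1 `COc1cc(Nc2nc3ccccc3nc2S(=O)(=O)c2ccccc2)cc(OC)c1` gives 140 nM, and compound 2 `Nc1cccc(Nc2nc3ccccc3nc2S(=O)(=O)c2ccccc2)c1` gives 2150 nM. The measured steps of a 110-fold higher number from compound 1 to compound 3 (2.04 log units; beyond the scatter) and a 7.1-fold higher number from compound 2 to compound 3 (0.85 log units; beyond the scatter) each exchange the whole aryl group on the nitrogen, as does a 15-fold higher number from compound 1 to compound 2 (1.19 log units; beyond the scatter). Compound 4 `O=S(=O)(c1ccccc1)c1nc2ccccc2nc1Nc1ccc(C(F)(F)F)cc1` differs from compound 3 only by trifluoromethyl in place of chloro on an aromatic carbon. Going by the values given here, no measured step exchanges one group for another on the same aryl ring, so the data give no direct guide to the size of this change. Compound 4 is expected to move by only a 1.0-fold lower number from compound 3 to compound 4 (0.01 log units; within the scatter), a step expected to stay within the scatter, and to give an estimated 15000 nM, between 5000 nM and 45000 nM.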

Compound 4, half-maximal inhibitory concentration: 3550 nM
Beside the measured number, compound 4's estimate is 4.2-fold (0.63 log units) above it, outside the stated range (below it).
By their numbers in this assay, from the lowest: compound 1; then compounds 2 and 4 (each within the scatter of the next); then compound 3.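

Trifluoromethyl in place of chloro on the aromatic carbon gives a 4.3-fold lower number from compound 3 to compound 4 (0.63 log units; beyond the scatter) in this assay, so this one group alone moves the number beyond the scatter while the rest of the molecule stays the same. The change leaves a 1.7-fold higher number from compound 2 to compound 4 (0.22 log units; within the scatter), yet still a 25-fold higher number from compound 1 to compound 4 (1.40 log units; beyond the scatter). Nothing at hand gives a reason for this change. Open, from the compounds shown here alone, is how a methoxy group, a nitrile or an amine at this same position would compare with chloro and trifluoromethyl.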